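Changing the aryl group of compound 2

The source may report more compounds than this note shows. Statements on the series, on what has been measured and on what is new or still open speak of the compounds shown alone.

Compound 1 `CCCCCCCCCCNC(=O)[C@@H]1CSC(c2ccc(OC)c(OC)c2)N1`: 6100 nM
Compound 2 `CCCCCCCCCCCCNC(=O)[C@@H]1CSC(c2ccc(OC)c(OC)c2)N1`: 1600 nM

Of the two compounds measured in a functional assay on WM164 cells (Homo sapiens) for antiproliferative activity, read by sulforhodamine B assay, with a stated time of 48 h (a higher number here means a weaker inhibitor, a lower number a stronger inhibitor), compound 2 has the lower number, 1600 nM. Among the measured compounds shown here, the only measured step, a 3.8-fold lower number from compound 1 to compound 2 (0.58 log units; beyond the scatter), lies in the saturated chain. Compound 3 `CCCCCCCCCCCCNC(=O)[C@@H]1CSC(c2ccc(N)cc2)N1` keeps the chain of compound 2 and has 4-aminophenyl in place of 3,4-dimethoxyphenyl on a saturated ring carbon. For the measured compounds named here, no measured step touches this group, so the data give neither a size nor a direction for the change, and no step beyond the scatter is expected. The expected change is a 1.1-fold higher number from compound 2 to compound 3 (0.05 log units; within the scatter). For compound 3 the estimated value is 1800 nM, with an expected range from 600 nM to 5500 nM.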

Compound 3, half-maximal inhibitory concentration: 1400 nM
Estimate against measurement, compound 3: 1.3-fold (0.11 log units) above; low and high end bracket the measured number.
By their numbers in this assay, from the lowest: compounds 3 and 2 (each within the scatter of the next); then compound 1.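

In this assay, the saturated ring carbon accepts a clear change of aryl group: 4-aminophenyl in place of 3,4-dimethoxyphenyl gives a 1.1-fold lower number from compound 2 to compound 3 (0.06 log units; within the scatter). With the chain of compound 2 kept, the two methoxy groups are therefore not required to hold the number at this level, even though the entering group also brings a hydrogen-bond donor that the leaving group lacks. Nothing available explains this result. As far as these compounds go, it remains open whether a carboxylic acid or a nitrile in place of the amine would leave the number within the scatter. Also open, from the compounds shown here alone, is whether 4-aminophenyl behaves the same way on the shorter chain of compound 1.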